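Adding Fluoro to the Longer-Lasting Compound

This account rests on a few compounds, and the source may have more. Where it says the series, first, only, none or still open, it means among the compounds named here.

Compound 1 `COC(=O)NC12CCC(n3cc(-c4ccc(Cl)c(N)c4)c4c(N)ncnc43)(CC1)CC2` gives 10 h
Compound 2 `COC(=O)N[C@H]1CC[C@@H](n2cc(-c3ccc(Cl)c(N)c3)c3c(N)ncnc32)CC1` gives 3 h

In an ADME assay on the whole organism (Mus musculus, strain BALB/c) for metabolic stability, read by LC-MS, at a dose of 2 mg/kg by the intravenous route (a lower number here means that the compound disappears faster, a higher number that the compound lasts longer), compound 1 stands highest of the two measured compounds, and compound 2 sits lower by a gap beyond the usual scatter. That gap comes from a different part of the structure, so it offers no direct guide to the change followed here.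

Compound 3 `COC(=O)NC12CCC(n3cc(-c4cc(N)c(Cl)cc4F)c4c(N)ncnc43)(CC1)CC2` keeps the core of compound 1 and changes it in one place (fluoro in place of hydrogen on an aromatic carbon). Fluoro takes the place of hydrogen on an aromatic carbon, which turns 3-amino-4-chlorophenyl into 5-amino-4-chloro-2-fluorophenyl.

For the measured compounds named here, no measured pair shows what this swap does in this assay so the expectation has little to lean on. It starts from compound 1 (10 h) and treats the swap as a small edit. The estimated step (a 1.1-fold lower number from compound 1 to compound 3 (0.05 log units; within the scatter)) is expected to stay within the usual scatter, with no firm direction. For compound 3 the expected half-life is (9 h), with an estimated range from 4.5 h to 18 h for repeated measurements.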

Compound 3, half-life: 16 h
Compound 3: middle estimate off by 1.8-fold (0.25 log units), on the low side; the measured number falls inside the stated range.
By their numbers in this assay, from the lowest: compound 2; then compounds 1 and 3 (each within the scatter of the next).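

For the compounds shown here, this is the first measured step for this spot on the ring, the aromatic carbon ortho to a large group, meta to a chloro group and para to an amino group. In this assay the swap of hydrogen for fluoro gives a 1.6-fold higher number from compound 1 to compound 3 (0.20 log units; within the scatter), so on the core of compound 1 this single added atom leaves the half-life indistinguishable from that of the parent, and the step cannot be read as a real gain. Nothing available explains why the half-life holds steady through this change, and one pair cannot establish a general rule for the swap.

Going by these compounds, it remains open whether this carbon would accept something other than fluoro, such as a nitrile or a trifluoromethyl group, with the half-life still staying within the scatter of compound 1. On these data alone, it is also open whether the same swap would behave in the same way on the core of compound 2, whose half-life lies well apart from that of compound 1 and whose structure differs elsewhere.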